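Shortening the chain from compound 2 to compound 3

The source may hold more compounds than are shown below. What is called first, only, known or untested is meant among the compounds shown, and "the series" means these compounds.

Compound 1, `ClCCCc1cc[nH]n1`: 40000 nM in an assay for inhibition of alcohol dehydrogenase (Equus caballus), read by spectrophotometry, in the presence of a further agent that is not named here; a lower number here means tighter binding, a higher number weaker binding.
Compound 2, `OCCCc1cc[nH]n1`: 60000 nM.

Among the measured compounds shown here, compound 2 has the higher of the two numbers in this assay; its only neighbour is compound 1, with a 1.5-fold higher number from compound 1 to compound 2 (0.18 log units; within the scatter). Compound 3, `OCCc1cc[nH]n1`, differs from compound 2 by hydroxy in place of hydroxymethyl on a saturated chain carbon, two bonds along the chain from an aromatic carbon. For the measured compounds named here, no measured step shortens the chain; the single step at hand, a 1.5-fold higher number from compound 1 to compound 2 (0.18 log units; within the scatter), exchanges one end group for another at fixed chain length and stays within the scatter. Because of a 1.5-fold higher number from compound 1 to compound 2 (0.18 log units; within the scatter) the change at this end of the chain is expected to matter little, so for compound 3 no step beyond the scatter is expected: a 1.3-fold higher number from compound 2 to compound 3 (0.12 log units; within the scatter). Compound 3 is expected to give about 80000 nM, between 30000 nM and 200000 nM.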

Compound 3, dissociation constant: 170000 nM
The estimate for compound 3 lay 2.1-fold (0.33 log units) below the measured number; low and high end bracket the measured number.
By their numbers in this assay, from the lowest: compounds 1 and 2 (each within the scatter of the next); then compound 3.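

In this assay, among the compounds shown here, hydroxy in place of hydroxymethyl on a saturated chain carbon, two bonds along the chain from an aromatic carbon, gives a 2.8-fold higher number from compound 2 to compound 3 (0.45 log units; beyond the scatter), the first step beyond the scatter, so this position responds to the shorter chain, though only modestly. Hydroxy in place of chloromethyl at the same place gives a 4.3-fold higher number from compound 1 to compound 3 (0.63 log units; beyond the scatter). Nothing available explains this weaker binding.

The effect of chain length rests on these few compounds, all with a short chain. On these data alone, whether a longer chain, or an amine or a carboxylic acid at the chain end, would tighten binding remains open.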